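Chloro on the benzamide ring of a weakly active series

The source may report more compounds than this note shows. Statements on the series, on what has been measured and on what is new or still open speak of the compounds shown alone.

Compound 1 `O=C(Nc1ccc(Cl)c(-c2nnc3c(Cl)cccn23)c1)c1cccnc1`: in a functional assay on MCF7 cells (Homo sapiens) for antiproliferative activity, read by MTT assay, with a stated time of 72 h (on this read-out lower numbers stand for stronger inhibition and higher numbers for weaker inhibition), compound 1 gives > 100000 nM, a limit of the assay.
Compound 2 `CS(=O)(=O)c1ccc(C(=O)Nc2ccc(Cl)c(-c3nnc4c(Cl)cccn34)c2)cc1`: in this assay compound 2 gives 94200 nM.

Compound 2 holds the only number shown; the other value is a limit (the limit of > 100000 nM in this assay, at which 1 of the 2 values shown sits). The step of an at least 1.0-fold lower number from compound 1 to compound 2 (0.02 log units; that floor lies within the scatter) sits within the scatter. Compound 3 `CS(=O)(=O)c1ccc(C(=O)Nc2ccc(Cl)c(-c3nnc4c(Cl)cccn34)c2)c(Cl)c1` differs from compound 2 by chloro in place of hydrogen on an aromatic carbon. For the measured compounds named here, no measured step touches this aromatic carbon, and the one step known, an at least 1.0-fold lower number from compound 1 to compound 2 (0.02 log units; that floor lies within the scatter), exchanged the whole aryl without moving the read-out beyond scatter. A step beyond the scatter is therefore not expected. Compound 3 is estimated at 80000 nM (range 30000 nM to 200000 nM), an expected step of a 1.2-fold lower number from compound 2 to compound 3 (0.07 log units; within the scatter).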

Compound 3, half-maximal inhibitory concentration: > 100000 nM
Compound 3: no number, only a limit (the forecaster's own chance of this, stated with the estimate: 40%); at least 1.2-fold (0.09 log units) between middle value and limit.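

For the compounds shown here, on this aromatic carbon, ortho to a large group and meta to a methylsulfonyl group, chloro in place of hydrogen gives an at least 1.0-fold higher number from compound 2 to compound 3 (0.02 log units; that floor lies within the scatter), the only reading at this position and a floor rather than a full step. Compound 3 gives > 100000 nM in this assay, a limit of the assay. Most of the series now rests at that limit: the limit of > 100000 nM in this assay, at which 2 of the 3 values shown sit.

As far as these compounds go, whether an amine or a carboxylic acid on this same carbon would give a number clearly away from the limit stays open. From the compounds shown here alone, the true size of the chloro step also stays open.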